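The source may hold more compounds than are shown below. What is called first, only, known or untested is meant among the compounds shown, and "the series" means these compounds.

Compound 3 `Cc1cc(C)c(NC(=O)N(Cc2ccc(-c3cccs3)cc2)C2CCCCCC2)c(C)c1` is the only one of the three measured compounds that gives a number rather than a limit in a functional assay on a cell-free system (plasma) with sterol O-acyltransferase, Soat (Rattus norvegicus) as the target; on this read-out higher numbers stand for an effect only at larger amounts of compound and lower numbers for an effect already at smaller amounts: compound 3 gives 0.28 mg/kg. Compound 1 `O=C(Nc1c(F)cc(F)cc1F)N(Cc1ccc(-c2cccs2)cc1)C1CCCCCC1` reaches only a limit of the test, > 1 mg/kg. Compound 2 `CSc1cc(C)nc(SC)c1NC(=O)N(Cc1ccc(F)cc1)Cc1cccc(-c2cc[nH]n2)c1` also stops at a limit, < 0.1 mg/kg. For the measured compounds named here, the single measured step, an at least 3.5-fold lower number from compound 1 to compound 3 (0.55 log units; beyond the scatter), concerns another part of the molecule and so does not bear directly on the present change. Compound 4 `Cc1cc(C)c(NC(=O)N(Cc2ccc(-n3nccn3)cc2)C2CCCCCC2)c(C)c1` differs from compound 3 by 2H-1,2,3-triazol-2-yl in place of thiophen-2-yl on an aromatic carbon. Going by the values given here, with no comparable step among the measured compounds, a change within or only just beyond the scatter is expected, and compound 4 is estimated to give 0.35 mg/kg, between 0.12 mg/kg and 1 mg/kg. This expected step, a 1.3-fold higher number from compound 3 to compound 4 (0.10 log units; within the scatter), is accordingly small.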

Compound 4, dose for half-maximal effect: > 1 mg/kg
Compound 4 was reported as a limit (the forecaster's own chance of this, stated with the estimate: 20%); at least 2.8-fold (0.45 log units) between middle value and limit.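

For the compounds shown here, this is the first measured change at this position, on an aromatic carbon para to a large group, and it is not a neutral one: 2H-1,2,3-triazol-2-yl in place of thiophen-2-yl brings an at least 3.5-fold higher number from compound 3 to compound 4 (0.55 log units; beyond the scatter). Both groups are five-membered aromatic rings with no net charge, yet they read differently here. The full size of the step stays unknown, because one end of it is only a limit: the limit of > 1 mg/kg in this assay, at which 2 of the 4 values shown sit.

Still open, going by these compounds, is whether the extra ring nitrogens or the loss of the sulfur matters more. On these data alone, how a furan-2-yl ring, a plain phenyl ring or a dimethylamino group would read at this position also remains unknown.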